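Amino for hydroxy across two fused cores

This account rests on a few compounds, and the source may have more. Where it says the series, first, only, none or still open, it means among the compounds named here.

Compound 1 `Nc1nc(O)c2ncn(C3CCC(CO)C3)c2n1` carries a hydroxy group on its core, and in a functional assay on P388 cells (Mus musculus) for inhibition (on this read-out lower numbers stand for an effect already at smaller amounts and higher numbers for an effect only at larger amounts of compound), compound 1 gives only a limit, > 100 ug/mL, not a number. Compound 2 `Nc1nc(N)c2ncn(C3CCC(CO)C3)c2n1` differs from compound 1 by amino in place of hydroxy on an aromatic carbon and in this assay compound 2 gives 80 ug/mL. The step of an at least 1.2-fold lower number from compound 1 to compound 2 (0.09 log units; that floor lies within the scatter) rests on the limit of > 100 ug/mL in this assay, at which 1 of the 3 values shown sits, and so cannot be sized more closely than a floor.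

Compound 3 `Nc1nc(O)c2nnn(C3CCC(CO)C3)c2n1` is built on another core; how the core of compound 3 differs from the core of compound 1 is not broken down here. In this assay compound 3 gives 51 ug/mL; set against compound 2 this lies within the scatter of repeated measurements, so no order between compound 2 and compound 3 is claimed.

Compound 4 `Nc1nc(N)c2nnn(C3CCC(CO)C3)c2n1` has not been measured. It differs from compound 3 by amino in place of hydroxy on an aromatic carbon, the same change as that from compound 1 to compound 2, at the same place on the ring. Within the data shown here, only one measured instance of this change exists and its size is bounded by a limit, so the expectation for compound 4 stands on a thin footing: the earlier step was a lowering of the number whose floor sits within the scatter. A step of similar, modest size is expected, a 1.3-fold lower number from compound 3 to compound 4 (0.11 log units; within the scatter), with wide room either way. For compound 4 in this assay a value of 40 ug/mL is expected, estimated to fall between 18 ug/mL and 90 ug/mL.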

Compound 4, concentration for half-maximal effect: > 100 ug/mL
Compound 4: a limit, no number; the forecaster's own chance of this, stated with the estimate: 5%; at least 2.5-fold (0.39 log units) between middle value and limit.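

In this assay compound 4 gives > 100 ug/mL, which is a limit and not a number, so amino in place of hydroxy on the core of compound 3 can be read only as a floor: an at least 1.9-fold higher number from compound 3 to compound 4 (0.29 log units; that floor lies within the scatter). The direction of the step on the core of compound 1 does not recur on the core of compound 3, but with both steps bounded by a limit, this does not establish that the change behaves differently on the two cores: the same change on two cores in this assay, an at least 1.2-fold lower number (0.09 log units; that floor lies within the scatter) from compound 1 to compound 2 and an at least 1.9-fold higher number (0.29 log units; that floor lies within the scatter) from compound 3 to compound 4; the limit leaves it open whether they differ. The series therefore gives no reliable size for this change and no firm basis for carrying it from one core to the other, and limits restrict the data: the limit of > 100 ug/mL in this assay, at which 2 of the 4 values shown sit.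

From the compounds shown here alone, the actual size of each step remains open, as does whether another group on that aromatic carbon, such as a methoxy group, a chlorine atom or a thiol, would give readable numbers on both cores. Also open is whether a longer chain in place of the hydroxymethyl group would shift the values of these compounds on either core.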